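Two ring swaps on one shared core

This account rests on a few compounds, and the source may have more. Where it says the series, first, only, none or still open, it means among the compounds named here.

Compound 1 `CN(C)CCn1cnnc1-c1cc(Oc2ccc(NC(=O)N/N=C/c3cccc(Cl)c3Cl)cc2F)ccn1`: 13200 nM
Compound 2 `COc1cc(/C=N/NC(=O)Nc2ccc(Oc3ccnc(-c4nncn4CCN(C)C)c3)c(F)c2)cc(OC)c1OC`: 22500 nM

In a functional assay on U-87MG ATCC cells (Homo sapiens) for cytotoxicity, read by MTT assay, with a stated time of 72 h (a higher number here means a weaker inhibitor, a lower number a stronger inhibitor), compound 1 gives 13200 nM, the smaller of the two numbers shown, yet compound 2 with 22500 nM sits within the usual scatter of it, so the two do not separate. Among the compounds with values here, the only measured step, a 1.7-fold higher number from compound 1 to compound 2 (0.23 log units; within the scatter), is a ring swap at the same carbon and stays within the scatter.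

Compound 3 `CN(C)CCn1cnnc1-c1cc(Oc2ccc(NC(=O)N/N=C/c3ccc(O)cc3O)cc2F)ccn1` differs from compound 1 in one place: 2,4-dihydroxyphenyl in place of 2,3-dichlorophenyl on a carbon with a double bond to nitrogen. Within the data shown here, that earlier swap is the one step bearing on this change, and it moved little, so no step beyond the scatter is expected in either direction. Compound 3 is estimated at 15000 nM, within 5000 nM to 45000 nM. This estimate means a 1.1-fold higher number from compound 1 to compound 3 (0.06 log units; within the scatter) is expected.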

Compound 3, half-maximal inhibitory concentration: 15400 nM
Compound 3: the middle estimate sits 1.0-fold (0.01 log units) below what was measured, and the stated range covers the measured number.
By their numbers in this assay, from the lowest: compounds 1, 3 and 2 (each within the scatter of the next).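

Placing 2,4-dihydroxyphenyl on this carbon brings 2 hydrogen-bond donors and 2 hydrogen-bond acceptors that 2,3-dichlorophenyl lacks, yet this assay shows only a 1.2-fold higher number from compound 1 to compound 3 (0.07 log units; within the scatter). Set against 3,4,5-trimethoxyphenyl, the same group gives a 1.5-fold lower number from compound 2 to compound 3 (0.16 log units; within the scatter), so these three differently substituted rings do not separate at this position. Nothing measured here explains this lack of separation.

Still open, going by these compounds, is whether a ring carrying an amine or a carboxylic acid, or a longer chain in place of the ring, would produce a step beyond the scatter.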